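The source may hold more compounds than are shown below. What is called first, only, known or untested is meant among the compounds shown, and "the series" means these compounds.

Working notes on the series. Compound 1 `O=c1cc(Cn2cc(C3CC3)nn2)c2ccc(O)cc2o1` gives only a limit in a functional assay on SW-620 cells (Homo sapiens) for inhibition, read by MTT assay, with a stated time of 72 h (on this read-out lower numbers stand for stronger inhibition and higher numbers for weaker inhibition), namely > 100000 nM. Compound 2 `CC(O)c1cn(Cc2cc(=O)oc3cc(O)ccc23)nn1` likewise gives only a limit in this assay, > 100000 nM. Compound 3 `CC(C)(C)c1cn(Cc2cc(=O)oc3cc(O)ccc23)nn1` also gives only a limit in this assay, > 100000 nM. The steps a step that the two limits leave unreadable from compound 1 to compound 2, a step that the two limits leave unreadable from compound 1 to compound 3 and a step that the two limits leave unreadable from compound 2 to compound 3 therefore carry no readable size; all three measured values sit at the limit of > 100000 nM in this assay, at which 3 of the 3 values shown sit. Compound 4 `O=c1cc(Cn2cc(CCc3ccccc3)nn2)c2ccc(O)cc2o1` differs from compound 1 by phenethyl in place of cyclopropyl on an aromatic carbon. Going by the values given here, none of the measured steps bears on this change with a readable size, and no measured compound in the set gives a number to build from. Compound 4 is expected to remain near the limit, so the step of a number no higher from compound 1 to compound 4 (the limit leaves the size open) is expected to be small or itself unreadable. The estimate for compound 4 in this assay is 100000 nM, ranging from 20000 nM to 500000 nM.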

Compound 4, half-maximal inhibitory concentration: 84400 nM
Compound 4: the middle estimate sits 1.2-fold (0.07 log units) above what was measured; low and high end bracket the measured number.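

Phenethyl at this position gives the first actual number of the series in this assay, with an at least 1.1-fold lower number from compound 1 to compound 4 (0.07 log units; that floor lies within the scatter). Against the other two groups the picture is the same, with an at least 1.1-fold lower number from compound 3 to compound 4 (0.07 log units; that floor lies within the scatter) and an at least 1.1-fold lower number from compound 2 to compound 4 (0.07 log units; that floor lies within the scatter). Replacing these groups with phenethyl therefore brings no step shown beyond the scatter, and most of the series stays at the limit: the limit of > 100000 nM in this assay, at which 3 of the 4 values shown sit.

On these data alone, the steps among compound 1, compound 2 and compound 3 cannot be read, and the true size of the steps to compound 4 remains open. As far as these compounds go, whether a longer chain or an amine in place of phenethyl would give a clear step also remains open.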